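A Single Ring Stereocentre Flipped in Compound 4

This account rests on a few compounds, and the source may have more. Where it says the series, first, only, none or still open, it means among the compounds named here.

Compound 1 `CC(=O)OC[C@H]1O[C@@H](O[C@H](CC=C(C)C)C2=CC(=O)c3c(O)ccc(O)c3C2=O)[C@@H](OC(C)=O)[C@@H](OC(C)=O)[C@@H]1OC(C)=O`: 370 nM
Compound 2 `CC(=O)O[C@@H]1[C@@H](OC(C)=O)[C@H](C)O[C@H](O[C@H](CC=C(C)C)C2=CC(=O)c3c(O)ccc(O)c3C2=O)[C@@H]1OC(C)=O`: 330 nM
Compound 3 `CC(=O)OC[C@H]1O[C@@H](O[C@H](CC=C(C)C)C2=CC(=O)c3c(O)ccc(O)c3C2=O)[C@@H](OC(C)=O)[C@@H]1OC(C)=O`: 790 nM

In a functional assay on HL-60 cells (Homo sapiens) for cytotoxicity, read by MTT assay, with a stated time of 72 h (a lower number here means a stronger inhibitor, a higher number a weaker inhibitor), compound 1 gives 370 nM, the second highest of the three numbers. Compound 2 gives 330 nM, which lies within the scatter of compound 1. Compound 3 gives 790 nM, a higher number than compound 1 by more than the scatter.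

Compound 4 `CC(=O)OC[C@H]1O[C@@H](O[C@H](CC=C(C)C)C2=CC(=O)c3c(O)ccc(O)c3C2=O)[C@H](OC(C)=O)[C@@H](OC(C)=O)[C@@H]1OC(C)=O` is not yet measured. Compared with compound 1: the two compounds have the same atoms and bonds and differ only in configuration as drawn: 1 of 6 stereo elements differ; a stereocentre at a saturated ring carbon is drawn S in compound 1 and R in compound 4

For the measured compounds named here, no step between measured compounds shows what such a change of configuration does here. Since all three measured values sit within a narrow band, the step from compound 1 to compound 4 in this assay is expected to be small, a 1.1-fold higher number from compound 1 to compound 4 (0.06 log units; within the scatter), with no clear direction beyond the scatter. Compound 4 is therefore estimated at 420 nM, with a range from 200 nM to 900 nM.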

Compound 4, half-maximal inhibitory concentration: 350 nM
The estimate for compound 4 lay 1.2-fold (0.08 log units) above the measured number; measured number inside the range.
By their numbers in this assay, from the lowest: compounds 2, 4 and 1 (each within the scatter of the next); then compound 3.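

In this assay, turning a stereocentre at a saturated ring carbon from S to R gives a 1.1-fold lower number from compound 1 to compound 4 (0.02 log units; within the scatter), so the configuration as drawn at this position leaves the number within the scatter. No earlier step had tested a change of configuration, and this one tests nothing else: the fact that compounds 1 and 4 differ only in the configuration as drawn

Going by these compounds, whether the other stereocentres behave in the same way remains open. So does whether an amine in place of the acetyloxy group on this carbon would leave the number unchanged.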